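The compounds below may be only part of what the source reports. "The series", "measured", "known", "first", "only" and "open" are said of these compounds alone.

Compound 1 `Cc1csc2cc([C@H](C)Nc3ncnc(N)c3C#N)c(-c3cccc(CN(C)CCCCN(C)Cc4ccccc4)c3)c(=O)n12`: 7.4%
Compound 2 `Cc1csc2cc([C@H](C)Nc3ncnc(N)c3C#N)c(-c3ccccc3)c(=O)n12`: 0%
Compound 3 `Cc1csc2cc([C@H](C)Nc3ncnc(N)c3C#N)c(Cc3cccc(CN(C)CC(C)C)c3)c(=O)n12`: 0%

These three share one core and were each tested in an ADME assay on the whole organism (lung, Rattus norvegicus) for metabolic stability, read by LC-MS, with a stated time of 24 h; a lower number here means that less of the compound is left, a higher number that more of the compound is left. Compound 3 sits level with compound 2 at the bottom of the three numbers, and the gap up to compound 1 is small enough to fall within the ordinary scatter, so no real order among them can be read from these values.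

Compound 4 `Cc1csc2cc([C@H](C)Nc3ncnc(N)c3C#N)c(Cc3cccc(CN4CCC4)c3)c(=O)n12` is the next compound, differing from compound 3 in a single place: azetidin-1-yl in place of isobutyl(methyl)amino on a saturated chain carbon bound to an aromatic carbon. Among the measured compounds no pair differs in exactly one place, so no earlier step gives guidance. The change is expected to bring no step beyond the scatter, that is a number 2 percentage points higher from compound 3 to compound 4 (within the scatter). Compound 4 is therefore estimated at 2%, with a range from 0% to 12%.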

Compound 4, percent of the compound remaining in the lung assay: 0%
For compound 4 the middle estimate is 2 percentage points above the measured one; measured number inside the range.
By their numbers in the lung assay, from the lowest: compounds 2, 3, 4 and 1 (each within the scatter of the next).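

In the lung assay the swap of isobutyl(methyl)amino for azetidin-1-yl gives no change at the digits printed from compound 3 to compound 4 (within the scatter) at this saturated chain carbon, so this first step at the position moves nothing there. In a physicochemical assay for lipophilicity (a lower number here means a more polar compound, a higher number a more lipophilic compound), compound 3 gives 2.3 and compound 4 gives 0.5 with a number 1.80 log units lower from compound 3 to compound 4 (beyond the scatter) for the same swap. One change in this place can therefore shift one read-out greatly while the other stays put.

Going by these compounds, whether a carboxylic acid or a longer chain here would lift the number in the lung assay remains open.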